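The source may hold more compounds than are shown below. What is called first, only, known or untested is meant among the compounds shown, and "the series" means these compounds.

Measured compounds and their values:

compound 1, `NC(=O)c1ccc2ccc(C(=O)c3ccccc3)c-2cc1`, 13.6%
compound 2, `O=C(Oc1ccc2ccc(Cl)ccc1-2)c1ccccc1`, 0.1%
compound 3, `O=C(Oc1ccc2ccc(Cl)ccc1-2)c1cccs1`, 9.8%

In an assay on cells for displacement of a labelled ligand from Orexin/Hypocretin receptor type 1 (Homo sapiens), read by scintillation counting, with stated times of 10 min and 90 min, tested at 10 uM (on this read-out lower numbers stand for less inhibition and higher numbers for more inhibition at the one concentration tested (going by the name of the read-out)), compound 3 stands second highest of the three numbers. Its nearest neighbour is compound 1, whose value in this assay lies within the scatter of the value of compound 3, and its furthest is compound 2, whose value in this assay also lies within the scatter of that of compound 3. All three numbers therefore sit close together at the low end of the read-out.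

The next compound is compound 4, `O=C(Oc1ccc2ccc(Cl)ccc1-2)c1cccnc1`. It differs from compound 3 in one place: pyridin-3-yl in place of thiophen-2-yl on a carbonyl carbon. For the measured compounds named here, the one measured step that bears on this change is the exchange of the aryl group on the same carbonyl carbon, a number 9.7 percentage points higher from compound 2 to compound 3 (within the scatter), which stayed within the scatter. On that basis no step beyond the scatter is expected in this assay for the present exchange either, in no particular direction.

Compound 4 is therefore expected to give 7%, with a range from -5% to 20%. The estimated step of a number 2.8 percentage points lower from compound 3 to compound 4 (within the scatter) thus lies within the scatter.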

Compound 4, a percentage reported as inhibition, at one concentration (the size of the read-out at that concentration, not a potency): -2.4%
Estimate against measurement, compound 4: 9.4 percentage points above; the measured number falls inside the stated range.
By their numbers in this assay, from the lowest: compounds 4, 2, 3 and 1 (each within the scatter of the next, the first and the last beyond it).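

In this assay, for the compounds shown here, exchanging the group on this carbonyl carbon now gives a step beyond the scatter: pyridin-3-yl in place of thiophen-2-yl gives a number 12.2 percentage points lower from compound 3 to compound 4 (beyond the scatter) and is the first change at this position to do so, though the step is modest. Pyridin-3-yl in place of phenyl gives a number 2.5 percentage points lower from compound 2 to compound 4 (within the scatter) and thiophen-2-yl in place of phenyl gives a number 9.7 percentage points higher from compound 2 to compound 3 (within the scatter), so phenyl cannot be separated from either of the other two groups, and only thiophen-2-yl and pyridin-3-yl stand apart, with all three values still at the low end of the read-out. Nothing at hand accounts for the difference between this pair.

Going by these compounds, what remains open is whether any group on this carbonyl carbon can lift the number well clear of this low range, for instance pyridin-2-yl, pyridin-4-yl, a furan ring, or a phenyl ring carrying an amine or a carboxylic acid. On these data alone, it is also open whether the step between thiophen-2-yl and pyridin-3-yl would persist if the chlorine on the shared core gave way to another atom or to a methoxy group.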